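A few compounds are considered here, and "the series" means these few. Any claim that something is new, unique, unknown or untested is made for them only; others in the source may bear on it.

Measured compounds:
- Compound 1, `O=C(c1cccc(F)c1)N1CC(c2nc(-c3cccc(Cl)c3)no2)C1`: in an assay on HEK293 cells for negative allosteric modulation of metabotropic glutamate receptor 5 (Homo sapiens), read by FLIPR (on this read-out lower numbers stand for stronger inhibition and higher numbers for weaker inhibition), compound 1 gives 780 nM.
- Compound 2, `O=C(C1CCC(F)(F)CC1)N1CC(c2nc(-c3cccc(Cl)c3)no2)C1`: in this assay compound 2 gives > 10000 nM, which is a limit of the assay and not a number.

Compound 2 thus stands at the weak end of the two values shown; it sits at the limit of > 10000 nM in this assay, at which 1 of the 2 values shown sits, so its true value is known only as lying at or beyond that boundary. Compound 3, `O=C(N1CCCCCC1)N1CC(c2nc(-c3cccc(Cl)c3)no2)C1`, differs from compound 2 in one place: azepan-1-yl in place of 4,4-difluorocyclohexyl on a carbonyl carbon. For the measured compounds named here, the only measured step that touches this position is an at least 12-fold higher number from compound 1 to compound 2 (1.10 log units; beyond the scatter), where a flat aromatic group gave way to a saturated ring and inhibition fell sharply. Compound 3 again carries a saturated ring on the carbonyl carbon, so the expectation is that it stays in the weak region rather than returning to the level of compound 1. Because compound 2 gives only the limit > 10000 nM, the step of an at least 1.2-fold lower number from compound 2 to compound 3 (0.09 log units; that floor lies within the scatter) is expected to be small and cannot be pinned down precisely. Compound 3 is therefore estimated at 8000 nM, within a range of 2000 nM to 30000 nM.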

Compound 3, half-maximal inhibitory concentration: > 10000 nM
Compound 3: no number, only a limit (the forecaster's own chance of this, stated with the estimate: 50%); middle value at least 1.2-fold (0.09 log units) away from the limit.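

In this assay compound 3 gives > 10000 nM, which is a limit of the assay and not a number. Azepan-1-yl in place of 3-fluorophenyl on the carbonyl carbon produces an at least 12-fold higher number from compound 1 to compound 3 (1.10 log units; beyond the scatter), so the weak end of the assay is reached with a saturated ring attached through a ring nitrogen as well as with one attached through a ring carbon. The step from compound 2 to compound 3 cannot be read, and the two saturated rings can be neither ranked nor told apart, as both compounds rest on the same boundary: the limit of > 10000 nM in this assay, at which 2 of the 3 values shown sit.

Compound 1 remains the only compound shown with a measured number and the only one with an aromatic ring at this place, so it is still open whether the aromatic ring itself matters or whether the fluorine on it plays a part. A plain phenyl, a pyridine ring or a small open chain such as ethyl on the carbonyl carbon would help to separate these possibilities and show how much inhibition this position can keep.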